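The compounds below may be only part of what the source reports. "The series", "measured", "known", "first", "only" and "open" are said of these compounds alone.

Measured compounds: compound 1 `O=C(CN1CCN(S(=O)(=O)c2ccc(F)cc2)CC1)Nc1ccc(F)cc1` gives 13800 nM in an in vitro assay on HEK ts201 cells for negative allosteric modulation of Neuronal acetylcholine receptor; alpha4/beta2 (Homo sapiens), read by fluorescence and calcium flux, with a stated time of 1.5 s; on this read-out higher numbers stand for weaker inhibition and lower numbers for stronger inhibition; compound 2 `O=C(CN1CCN(S(=O)(=O)c2ccccc2F)CC1)Nc1ccc(F)cc1` gives 8000 nM in this assay.

Compound 2 sits beside compound 1 with a gap of a 1.7-fold lower number from compound 1 to compound 2 (0.24 log units; within the scatter), so the two numbers cannot be told apart. Compound 3 `COc1ccc(S(=O)(=O)N2CCN(CC(=O)Nc3ccc(F)cc3)CC2)cc1` has not been measured. It differs from compound 2 in one place: 4-methoxyphenyl in place of 2-fluorophenyl on a sulfonyl sulfur. For the measured compounds named here, the only measured step that concerns this part of the molecule is the one on the same sulfonyl sulfur, a 1.7-fold lower number from compound 1 to compound 2 (0.24 log units; within the scatter), and it stayed within the scatter. Going by the values given here, no measured step shows what a methoxy group on this ring does, so nothing beyond the scatter is expected from the exchange. Compound 3 is therefore estimated to give 9000 nM in this assay, with a range from 3000 nM to 30000 nM. That estimate means a step of a 1.1-fold higher number from compound 2 to compound 3 (0.05 log units; within the scatter), which is expected to lie within the scatter.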

Compound 3, half-maximal inhibitory concentration: 23800 nM
Estimate against measurement, compound 3: 2.6-fold (0.42 log units) below; the measured number falls inside the stated range.
By their numbers in this assay, from the lowest: compounds 2, 1 and 3 (each within the scatter of the next, the first and the last beyond it).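

For the compounds shown here, on a sulfonyl sulfur, 4-methoxyphenyl in place of 2-fluorophenyl gives the first step at this position in this assay that clears the scatter, with a 3.0-fold higher number from compound 2 to compound 3 (0.47 log units; beyond the scatter) and so a modest loss of inhibition on this read-out. Methoxy in place of fluoro on an aromatic carbon gives only a 1.7-fold higher number from compound 1 to compound 3 (0.24 log units; within the scatter) and cannot be told from the scatter, so the one clear gap lies between the two ends of this set of three compounds. Nothing measured here explains either step.

On these data alone, what an amine or a carboxylic acid on this ring would do stays open. Also open, as far as these compounds go, is whether a plain phenyl on the same sulfonyl sulfur would give a number clearly apart from these three.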